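Methyl on the Phenol Oxygen: Estimating Compound 4

The compounds below may be only part of what the source reports. "The series", "measured", "known", "first", "only" and "open" are said of these compounds alone.

Measured so far in a functional assay on PC-3 cells (Homo sapiens) for inhibition, read by sulforhodamine B assay, with a stated time of 48 h; on this read-out lower numbers stand for stronger inhibition of growth and higher numbers for weaker inhibition of growth:

Compound 1 `CC1(/C=C/c2ccccc2O)C=CC(=O)O1` gives 112000 nM
Compound 2 `CC1(/C=C/c2ccc(O)cc2)C=CC(=O)O1` gives 138000 nM
Compound 3 `COc1ccccc1/C=C/C1(C)C=CC(=O)O1` gives 34200 nM

Compound 1 and compound 2 share the same atoms joined differently; the difference between the two cores is not broken down here. Their values in this assay are within the usual scatter of each other, so no order between them can be read from the numbers.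

Compound 3 differs from compound 1 by one change: methyl in place of hydrogen on an oxygen on an aromatic ring. That change gave a 3.3-fold lower number from compound 1 to compound 3 (0.52 log units; beyond the scatter), a modest but real step in this assay.

Compound 4 `COc1ccc(/C=C/C2(C)C=CC(=O)O2)cc1` has not yet been measured. Within the data shown here, it differs from compound 2 by methyl in place of hydrogen on an oxygen on an aromatic ring, the same change as the one from compound 1 to compound 3, at a place described in the same words. Among the measured compounds shown here, only one earlier example of this change is available, so the expectation rests on a single step. Starting from compound 2, a step of about the same size is expected, because a 3.3-fold lower number from compound 1 to compound 3 (0.52 log units; beyond the scatter) is the only guide on hand. Compound 4 is therefore expected to give 45000 nM in this assay, with a plausible range from 20000 nM to 140000 nM. That estimate means an expected step of a 3.1-fold lower number from compound 2 to compound 4 (0.49 log units; beyond the scatter).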

Compound 4, concentration for total growth inhibition: 145000 nM
Compound 4: middle estimate off by 3.2-fold (0.51 log units), on the low side, and the stated range ends below it.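

In this assay the new step reads a 1.1-fold higher number from compound 2 to compound 4 (0.02 log units; within the scatter) and so no effect of putting methyl in place of hydrogen on the oxygen can be read on the core of compound 2. Set beside the earlier step, this shows that the same change did not carry over from one core to the other in this series, since the two steps stand further apart than scatter alone would explain: the same change on two cores in this assay, a 3.3-fold lower number (0.52 log units; beyond the scatter) from compound 1 to compound 3 and a 1.1-fold higher number (0.02 log units; within the scatter) from compound 2 to compound 4, 3.4-fold (0.54 log units) apart, beyond the scatter of two such steps

Among these compounds, with only two pairs, this shows that the result of the change depended on the core in these compounds, but it does not show why, which of the two steps is more typical, or what would happen on any further core.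

The compounds shown carry only hydroxy or methoxy at this place, so a longer chain on the oxygen, such as ethyl, remains open, as does an amine in place of the hydroxy. Whether either of these would follow the step seen on the core of compound 1 or the one seen on the core of compound 2 cannot be told from these compounds.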